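Extending the acrylamide chain in an antiproliferative series

The source may report more compounds than this note shows. Statements on the series, on what has been measured and on what is new or still open speak of the compounds shown alone.

Compound 1, `CC(C)=CC(=O)Nc1cccc(Oc2nc(Nc3ccn(C)n3)nc3c2CSCC3)c1`, in a functional assay on A549 cells (Homo sapiens) for antiproliferative activity, read by MTT assay, with a stated time of 72 h (a lower number here means a stronger inhibitor, a higher number a weaker inhibitor), gives 44200 nM.
Compound 2, `CC(C)/C=C/C(=O)Nc1cccc(Oc2nc(Nc3ccn(C)n3)nc3c2CSCC3)c1`, in this assay gives 33500 nM.
Compound 3, `COc1ccc(Nc2nc3c(c(Oc4cccc(NC(=O)C=C(C)C)c4)n2)CSCC3)cn1`, in this assay gives 16800 nM.

Compound 4 is `COc1ccc(Nc2nc3c(c(Oc4cccc(NC(=O)/C=C/C(C)C)c4)n2)CSCC3)cn1` and has not yet been measured. It differs from compound 3 by 3-methylbut-1-en-1-yl in place of 2-methylprop-1-en-1-yl on a carbonyl carbon. The same change has already been made once, from compound 1 to compound 2, where it is 3-methylbut-1-en-1-yl in place of 2-methylprop-1-en-1-yl on a carbonyl carbon and gave a 1.3-fold lower number from compound 1 to compound 2 (0.12 log units; within the scatter). The place around the change is the same in both pairs, so this is the same change. The two cores differ by 6-methoxypyridin-3-yl in place of 1-methyl-1H-pyrazol-3-yl on a nitrogen on an aromatic ring, a change that gave a 2.6-fold lower number from compound 1 to compound 3 (0.42 log units; beyond the scatter).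

The expected step is a 1.3-fold lower number from compound 3 to compound 4 (0.11 log units; within the scatter), resting on the earlier step, a 1.3-fold lower number from compound 1 to compound 2 (0.12 log units; within the scatter), which lay within the scatter. Compound 4 is therefore estimated at 13000 nM, with a plausible range from 6500 nM to 26000 nM.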

Compound 4, half-maximal inhibitory concentration: 24200 nM
Compound 4: middle estimate off by 1.9-fold (0.27 log units), on the low side, and the stated range covers the measured number.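

In this assay, the change to 3-methylbut-1-en-1-yl on a carbonyl carbon gives a 1.4-fold higher number from compound 3 to compound 4 (0.16 log units; within the scatter), and this does not separate from the step seen on the other core: the same change on two cores in this assay, a 1.3-fold lower number (0.12 log units; within the scatter) from compound 1 to compound 2 and a 1.4-fold higher number (0.16 log units; within the scatter) from compound 3 to compound 4, 1.9-fold (0.28 log units) apart, within the scatter of two such steps. The change to 6-methoxypyridin-3-yl on the nitrogen, here a 1.4-fold lower number from compound 2 to compound 4 (0.14 log units; within the scatter), likewise stays in agreement with its earlier step: the same change on two cores in this assay, a 2.6-fold lower number (0.42 log units; beyond the scatter) from compound 1 to compound 3 and a 1.4-fold lower number (0.14 log units; within the scatter) from compound 2 to compound 4, 1.9-fold (0.28 log units) apart, within the scatter of two such steps. Both changes therefore carry from one core to the other without a detectable difference, but these four compounds do not show that either change has a fixed effect of a given size on every core.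

From the compounds shown here alone, it remains open how a chain ending in an amine would read on the carbonyl carbon. The same holds for a longer saturated chain in that place.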